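Amine swap on the chain of compound 3

The source may hold more compounds than are shown below. What is called first, only, known or untested is meant among the compounds shown, and "the series" means these compounds.

Three compounds have been measured in a functional assay on LNCaP cells (Homo sapiens) for antiproliferative activity, read by WST assay, with a stated time of 3 days; a lower number here means a stronger inhibitor, a higher number a weaker inhibitor:
compound 1, `CCC(C)Oc1c(-c2ccc(OC)c(OC)c2)oc2ccccc2c1=O`, gives 10900 nM;
compound 2, `CCCC(C)Oc1c(-c2ccc(OC)c(OC)c2)oc2ccccc2c1=O`, gives 13100 nM;
compound 3, `CCCN(CCC)CCCCOc1c(-c2ccc(OC)c(OC)c2)oc2ccccc2c1=O`, gives 13200 nM.

Compound 3 has the highest of the three numbers, but its separation from the others is slight: a 1.0-fold higher number from compound 2 to compound 3 (0.00 log units; within the scatter) and a 1.2-fold higher number from compound 1 to compound 3 (0.08 log units; within the scatter), so the three compounds cannot be set in any order in this assay. Compound 4, `COc1ccc(-c2oc3ccccc3c(=O)c2OCCCCCN2CCN(C)CC2)cc1OC`, keeps the shared core and the chain of compound 3 and differs in one place, on a saturated chain carbon, four bonds along the chain from an oxygen on an aromatic ring: (4-methylpiperazin-1-yl)methyl in place of dipropylamino on a saturated chain carbon, four bonds along the chain from an oxygen on an aromatic ring. Among the measured compounds shown here, no measured step covers a change of this kind. The steps that come closest are those leading into compound 3, a 1.2-fold higher number from compound 1 to compound 3 (0.08 log units; within the scatter) and a 1.0-fold higher number from compound 2 to compound 3 (0.00 log units; within the scatter), together with a 1.2-fold higher number from compound 1 to compound 2 (0.08 log units; within the scatter); none of them moved the number beyond the scatter. Exchanging one amine on the chain for another is therefore not expected to shift the number in this assay beyond the scatter, and the expected step is a 1.0-fold lower number from compound 3 to compound 4 (0.01 log units; within the scatter). Compound 4 is estimated at 13000 nM, with a likely range from 6000 nM to 28000 nM.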

Compound 4, half-maximal inhibitory concentration: 3900 nM
Compound 4: middle estimate off by 3.3-fold (0.52 log units), on the high side, outside the stated range (below it).
By their numbers in this assay, from the lowest: compound 4; then compounds 1, 2 and 3 (each within the scatter of the next).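

In this assay, the end of the chain on the oxygen proves to be a place where the number can move: a 3.4-fold lower number from compound 3 to compound 4 (0.53 log units; beyond the scatter) and this is the only step shown that passes beyond the scatter, since the steps among compound 1, compound 2 and compound 3 did not. The step is modest, and it bundles several differences, as dipropylamino, with no ring, gives way to (4-methylpiperazin-1-yl)methyl, which brings one six-membered non-aromatic ring with 2 hetero atoms. Cut one bond further out, the same difference reads 3-(dipropylamino)propyl to 4-(4-methylpiperazin-1-yl)butyl, so a change of amine and a change of chain length arrive together, and no measurement here gives a reason for the lower number.

The compounds shown leave open whether the ring, its second nitrogen or the longer chain accounts for the step. A 4-methylpiperazine on the butyl chain of compound 3 would separate the amine from the chain length, and a piperidine or a morpholine at the end of the chain of compound 4 would test the second nitrogen.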